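The source may hold more compounds than are shown below. What is called first, only, known or untested is meant among the compounds shown, and "the series" means these compounds.

Compound 1 `COc1cc(/C=C/C(=O)c2cccc(-c3cccc(F)c3)c2)ccc1O` gives 9900 nM
Compound 2 `O=C(/C=C/c1cccc(Br)c1)c1cccc(-c2cccc(F)c2)c1` gives 9120 nM
Compound 3 `COc1ccc(-c2cc(C(=O)/C=C/c3cc(OC)c(OC)c(OC)c3)ccc2N)cc1OC` gives 4620 nM

Going by the values given here, all three values come from a functional assay on A549 cells (Homo sapiens) for cytotoxicity, read by sulforhodamine B assay, with a stated time of 48 h (a higher number here means a weaker inhibitor, a lower number a stronger inhibitor), and they are the only measurements available. Compound 2 at 9120 nM lies within the scatter of compound 1 at 9900 nM and also of compound 3 at 4620 nM in this set.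

Compound 4 `O=C(/C=C/c1ccc(Cl)cc1)c1cccc(-c2cccc(F)c2)c1` has no value yet. It differs from compound 2 by 4-chlorophenyl in place of 3-bromophenyl on a double-bonded chain carbon bound to a double-bonded chain carbon with 4-chlorophenyl in place of 3-bromophenyl on a double-bonded chain carbon bound to a double-bonded chain carbon. Among the compounds with values here, no measured pair differs in one place only, so the data give no size for such a swap. In this assay no step beyond the scatter is expected in either direction. The estimate amounts to a step of a 1.1-fold lower number from compound 2 to compound 4 (0.03 log units; within the scatter) and no more than that is expected. Compound 4 is expected at 8500 nM with an estimated range from 4000 nM to 18000 nM for the coming measurement.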

Compound 4, half-maximal inhibitory concentration: 15400 nM
Beside the measured number, compound 4's estimate is 1.8-fold (0.26 log units) below it, within the range that was stated.
By their numbers in this assay, from the lowest: compounds 3, 2, 1 and 4 (each within the scatter of the next, the first and the last beyond it).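

Going by these compounds alone, this is the first pair in the set that differs in one place only, and it gives a size for a change at this position: in this assay, 4-chlorophenyl in place of 3-bromophenyl on a double-bonded chain carbon bound to a double-bonded chain carbon gives a 1.7-fold higher number from compound 2 to compound 4 (0.23 log units; within the scatter). The exchange of these two halogen-bearing phenyl groups therefore leaves the number within the scatter. No independent measurement accounts for this result.

A single pair cannot separate the change of halogen from the change in its numbered place on the ring, which a 3-chlorophenyl group would address. On these data alone, how an aminophenyl group or a carboxylic acid would read at this position remains open.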